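The compounds below may be only part of what the source reports. "The series", "measured", "known", "first", "only" and "open" are said of these compounds alone.

Measured so far:
Compound 1, `CC1=C(C(=O)Nc2ccc(F)cc2)C(c2ccc([N+](=O)[O-])cc2)N=C(SCc2ccccc2Cl)N1`, in a functional assay on the whole organism (artery, strain albino) with Rattus norvegicus as the target, with a stated time of 360 min, at a dose of 10 mg/kg by the oral route (a higher number here means more inhibition at the dose given (going by the name of the read-out), a lower number less inhibition), gives 21.6%.
Compound 2, `CC1=C(C(=O)Nc2ccc(F)cc2)C(c2ccc([N+](=O)[O-])cc2)N=C(SCc2cccc(Cl)c2)N1`, in this assay gives 21.1%.

Both compounds share one core and differ only in where the chlorine sits on the benzyl group joined to the sulfur. The two readings in this assay lie within the usual scatter of each other, so neither number can be called the higher: the step of a number 0.5 percentage points lower from compound 1 to compound 2 (within the scatter) is too small to be told from repeat measurement noise. Compound 2 thus stands at the same level as compound 1 on the numbers shown.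

Compound 3, `CC1=C(C(=O)Nc2ccc(F)cc2)C(c2ccc([N+](=O)[O-])cc2)N=C(SCc2ccc(Cl)cc2)N1`, is not yet measured. It differs from compound 2 only in the position of that chlorine: 4-chlorophenyl in place of 3-chlorophenyl on a saturated chain carbon bound to a sulfur. Within the data shown here, the one measured step that bears on this change is the earlier move of the chlorine, a number 0.5 percentage points lower from compound 1 to compound 2 (within the scatter), which left the reading unchanged within the scatter. Moving the chlorine once more is therefore expected to give a step of about a number 0.1 percentage points lower from compound 2 to compound 3 (within the scatter) in this assay, that is, none beyond the scatter. For compound 3 the expected value in this assay is 21%, with a range from 9% to 34%.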

Compound 3, a percentage reported as inhibition, in the whole organism at one dose (the size of the read-out at that dose, not a potency): 39.7%
Beside the measured number, compound 3's estimate is 18.7 percentage points below it; the whole stated range lies below it.
By their numbers in this assay, from the lowest: compounds 2 and 1 (each within the scatter of the next); then compound 3.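

Moving the chlorine around the ring is not always without effect, as the earlier pair of compounds might have suggested. In this assay, 4-chlorophenyl on the saturated chain carbon bound to the sulfur gives a number 18.6 percentage points higher from compound 2 to compound 3 (beyond the scatter), and the same change gives a number 18.1 percentage points higher from compound 1 to compound 3 (beyond the scatter). So among the three placings, the 2-chlorophenyl and 3-chlorophenyl groups remain level within the scatter, and only the 4-chlorophenyl group stands apart, while nothing shown explains why this placing differs from the other two.

On these data alone, all three compounds carry a chlorine on this ring, so it remains open whether the higher reading needs chlorine itself or would also appear with a 4-fluorophenyl, 4-bromophenyl or 4-methoxyphenyl group, or with a plain phenyl group carrying no substituent at all. Also open, as far as these compounds go, is whether it survives a longer chain between the sulfur and the ring, and, as each reading comes from a single dose and time, whether the gap between these compounds would hold at other doses.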